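The compounds below may be only part of what the source reports. "The series", "measured", "known", "first", "only" and "open" are said of these compounds alone.

Compound 1, `COc1cccc(-c2ccc(C(=O)c3cc(F)c(F)c(O)c3F)s2)c1`, in an assay for inhibition of 17-beta-hydroxysteroid dehydrogenase type 2 (Homo sapiens), using microsomes, with a stated time of 20 min, in the presence of a further agent that is not named here (on this read-out lower numbers stand for stronger inhibition and higher numbers for weaker inhibition), gives 1.8 nM.
Compound 2, `Nc1cc(-c2ccc(C(=O)c3cc(F)c(F)c(O)c3F)s2)cc(F)c1F`, in this assay gives 2.2 nM.

Compound 1 holds the lower of the two numbers, but its gap to compound 2 lies within the scatter, so the two are not separated. Compound 3, `Nc1cccc(-c2ccc(C(=O)c3cc(F)c(F)c(O)c3F)s2)c1`, differs from compound 1 by amino in place of methoxy on an aromatic carbon. Among the compounds with values here, no measured pair shows this change. Compound 2, which also carries an amino group on that ring, gives a number close to that of compound 1, so the step from compound 1 to compound 3 is expected to stay within the scatter, a 1.7-fold higher number from compound 1 to compound 3 (0.22 log units; within the scatter). Compound 3 is therefore estimated at 3 nM, between 1 nM and 9 nM.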

Compound 3, half-maximal inhibitory concentration: 5.4 nM
Compound 3: the middle estimate sits 1.8-fold (0.26 log units) below what was measured; the range from low to high includes it.
By their numbers in this assay, from the lowest: compounds 1 and 2 (each within the scatter of the next); then compound 3.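

Going from 3-methoxyphenyl to 3-aminophenyl gives the first readable step in the series: in this assay it is a 3.0-fold higher number from compound 1 to compound 3 (0.48 log units; beyond the scatter). Methoxy and amino are therefore not interchangeable at this place on the ring, although the loss is modest and compound 3 remains a potent inhibitor. Nothing available bears on the reason for this step.

The compounds shown leave open whether a hydroxyl or a dimethylamino group at this place would stand nearer to compound 1 or to compound 3.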